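The compounds below may be only part of what the source reports. "The series", "measured", "known", "first", "only" and "open" are said of these compounds alone.

Compound 1 `COc1ccc(C(=O)C2Sc3nnc(-c4cc(OC)c(OC)c(OC)c4)n3NC2c2ccco2)cc1` and its two measured partners share one core and differ only in the ring joined to the carbonyl carbon. In a functional assay on A549 cells (Homo sapiens) for cytotoxicity, read by MTT assay, with a stated time of 48 h (a lower number here means a stronger inhibitor, a higher number a weaker inhibitor), compound 1 gives > 100000 nM, which is a limit of the assay and not a number. Compound 3 `COc1cccc(C(=O)C2Sc3nnc(-c4cc(OC)c(OC)c(OC)c4)n3NC2c2ccco2)c1`, bearing 3-methoxyphenyl on the carbonyl carbon, gives > 100000 nM, again a limit. Compound 2 `COc1cc(-c2nnc3n2NC(c2ccco2)C(C(=O)c2cccc(Br)c2)S3)cc(OC)c1OC`, with 3-bromophenyl there, gives 36900 nM. Thus an at least 2.7-fold lower number from compound 1 to compound 2 (0.43 log units; beyond the scatter) and an at least 2.7-fold higher number from compound 2 to compound 3 (0.43 log units; beyond the scatter), while a step that the two limits leave unreadable from compound 1 to compound 3 owing to the limit of > 100000 nM in this assay, at which 2 of the 3 values shown sit. Compound 4 `COc1cc(-c2nnc3n2NC(c2ccco2)C(C(=O)c2ccc(F)cc2)S3)cc(OC)c1OC` is compound 1 with fluoro in place of methoxy on an aromatic carbon. The step that bears on it is the exchange of 4-methoxyphenyl for a halogen-bearing 3-bromophenyl, which lowered the number at least modestly; the reverse exchange of bromo for methoxy raised it by the same amount. Fluoro is also a halogen, though a different one on a different ring pattern, so a small move in the same direction is plausible but far from certain. On that basis the expected step is an at least 1.2-fold lower number from compound 1 to compound 4 (0.09 log units; that floor lies within the scatter). Compound 4 is therefore estimated at 80000 nM, within 25000 nM to 100000 nM.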

Compound 4, half-maximal inhibitory concentration: 53700 nM
Compound 4: the middle estimate sits 1.5-fold (0.17 log units) above what was measured, and the stated range covers the measured number.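

Fluoro in place of methoxy, para to a large group, gives an at least 1.8-fold lower number from compound 1 to compound 4 (0.27 log units; that floor lies within the scatter), and 4-fluorophenyl in place of 3-methoxyphenyl gives an at least 1.8-fold lower number from compound 3 to compound 4 (0.27 log units; that floor lies within the scatter). Among these four compounds, both halogen-bearing rings now give a readable number in this assay and neither methoxy-bearing ring does, with no compound against that pattern, while the halogen's identity and place make no clear difference: a 1.5-fold higher number from compound 2 to compound 4 (0.16 log units; within the scatter). The two methoxy compounds therefore set only floors, not true sizes, for their steps: the limit of > 100000 nM in this assay, at which 2 of the 4 values shown sit.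

From the compounds shown here alone, whether this pattern extends to chloro, or to a non-halogen group such as an amine or a carboxylic acid on the same ring, remains open. So does the real distance between the methoxy compounds and compound 4.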